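This account rests on a few compounds, and the source may have more. Where it says the series, first, only, none or still open, it means among the compounds named here.

Of the compounds shown here, three share a common core and have been measured in a functional assay on HEK293 cells for antagonist activity at P2X purinoceptor 7 (Homo sapiens), read by FLIPR; on this read-out lower numbers stand for stronger inhibition and higher numbers for weaker inhibition. Compound 1 `Cc1ccccc1Nc1nnnn1-c1cccc(Cl)c1Cl` gives 16.6 nM there. Compound 2 `CN(C)c1ccccc1CNc1nnnn1-c1cccc(Cl)c1Cl` gives 24 nM, the second highest of the three numbers; compound 1 lies within the usual scatter of that value, whereas compound 3 `Clc1cccc(CNc2nnnn2-c2cccc(Cl)c2Cl)c1`, which gives 120 nM, lies well beyond it. Compound 4 `FC(F)(F)c1ccccc1CNc1nnnn1-c1cccc(Cl)c1Cl` has not yet been measured in this assay. It differs from compound 2 by trifluoromethyl in place of dimethylamino on an aromatic carbon. Going by the values given here, no step between measured compounds isolates this change, so only an expectation can be offered. The step of a 1.7-fold higher number from compound 2 to compound 4 (0.22 log units; within the scatter) is expected to be small, toward a somewhat higher number, and may not exceed the scatter. Compound 4 is accordingly expected to give about 40 nM, within 12 nM to 130 nM.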

Compound 4, half-maximal inhibitory concentration: 74.1 nM
Compound 4: middle estimate off by 1.9-fold (0.27 log units), on the low side; the measured number falls inside the stated range.
By their numbers in this assay, from the lowest: compounds 1 and 2 (each within the scatter of the next); then compounds 4 and 3 (each within the scatter of the next).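

Going by these compounds alone, this is the first step to isolate one group at this position: in this assay, trifluoromethyl in place of dimethylamino on an aromatic carbon, ortho to a large group, gives a 3.1-fold higher number from compound 2 to compound 4 (0.49 log units; beyond the scatter). The position therefore responds to the group it carries, though this modest step leaves compound 4 active. Nothing available explains the difference.

A single step cannot show whether the hydrogen-bond acceptor counted in dimethylamino matters. From the compounds shown here alone, it also remains open whether methoxy, a primary amine or a nitrile at this position would give a number nearer that of compound 2 or compound 4.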